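This account rests on a few compounds, and the source may have more. Where it says the series, first, only, none or still open, it means among the compounds named here.

Compound 1, `O=C(CCCCCCc1ccccc1)c1nnn[nH]1`, is reported in an assay on isolated protein for inhibition of Fatty-acid amide hydrolase 1 (Homo sapiens) (a lower number here means a stronger inhibitor, a higher number a weaker inhibitor), only as a limit, > 1000 nM. Among the compounds with values here, compound 2, `CCCCCCCC/C=C\CCCCCCC(=O)c1ncc(-c2ccco2)o1`, gives 54 nM in this assay, and this is the single number among the two values shown. The other value shown belongs to compound 1 and is a limit, (the limit of > 1000 nM in this assay, at which 1 of the 2 values shown sits). Compound 3, `CCCCCCCC/C=C\CCCCCCC(=O)c1ncco1`, is not yet measured; it differs from compound 2 by hydrogen in place of furan-2-yl on an aromatic carbon. Within the data shown here, no measured pair differs in one place, yet a step beyond the usual scatter toward weaker inhibition is expected here in this assay, a 9.3-fold higher number from compound 2 to compound 3 (0.97 log units; beyond the scatter). Compound 3 is accordingly estimated at 500 nM, within a range from 150 nM to 2000 nM.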

Compound 3, inhibition constant: 17 nM
Estimate against measurement, compound 3: 29-fold (1.47 log units) above; measured number outside the range, below it.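

In this assay, hydrogen in place of furan-2-yl on this aromatic carbon, next to the ring oxygen, gives a 3.2-fold lower number from compound 2 to compound 3 (0.50 log units; beyond the scatter), so inhibition at this position does not depend on the furan-2-yl ring. Within the data shown here, this is the first pair that differs in one place, and it shows a modest gain in strength from removing the group. Nothing measured here gives a reason for this step.

Going by these compounds, whether a methyl group, a chlorine atom or a phenyl ring on this carbon would behave like hydrogen or like furan-2-yl stays open. So does whether the step would hold with a shorter saturated chain in place of the one shared by compound 2 and compound 3.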